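Fluorophenoxy replaces methoxyphenylthio on the shared core

The compounds below may be only part of what the source reports. "The series", "measured", "known", "first", "only" and "open" are said of these compounds alone.

Compound 3 `COc1ccc(Sc2nc3cc(N)cc(N)c3nc2-c2ccccc2)cc1` was tested in a functional assay on SW-620 cells (Homo sapiens) for inhibition, read by sulforhodamine B assay, with a stated time of 48 h; on this read-out lower numbers stand for higher toxicity in this test and higher numbers for lower toxicity in this test. For compound 3 the read-out is a limit of the assay, < 100000 nM. Compound 2 `CCOC(=O)[C@H](CCC(=O)O)NC(=O)c1ccc(CNc2nc3cc(N)cc(N)c3nc2-c2ccccc2)cc1` likewise shows only a limit, < 100000 nM. Going by the values given here, compound 1 `Nc1cc(N)c2nc(-c3ccccc3)c(Oc3ccc(Cl)c(Cl)c3)nc2c1` is the one compound with a number, 91200 nM. Among the compounds with values here, the single step that joins two measured compounds, a step that the limit leaves unreadable from compound 1 to compound 3, has no readable size due to the limit of < 100000 nM in this assay, at which 2 of the 3 values shown sit. Where compound 3 stands among the numbers is therefore not known beyond its limit.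

Compound 4 `Nc1cc(N)c2nc(-c3ccccc3)c(Oc3ccc(F)cc3)nc2c1` has not yet been measured. It differs from compound 3 by 4-fluorophenoxy in place of (4-methoxyphenyl)sulfanyl on an aromatic carbon. Within the data shown here, no measured step covers this exchange, and the only step available is unreadable, so it gives no size or direction to lean on. What remains is that compound 4 carries an aryloxy group on the same carbon of the core as compound 1, whose value is 91200 nM. On that ground compound 4 is expected to land near the value of compound 1 rather than far from it. The expected step, a step that the limit leaves unreadable from compound 3 to compound 4, cannot be judged against a limit. Compound 4 is estimated at 90000 nM, with a range from 30000 nM to 150000 nM, and a real chance that only a limit is reported.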

Compound 4, concentration lethal to 50% of the cells: < 100000 nM
Compound 4: only a limit was reported (the forecaster's own chance of this, stated with the estimate: 45%); the middle value lies beyond the limit too.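

Neither the step from compound 3 to compound 4 nor the step from compound 1 to compound 4 can be read, because compound 3 and compound 4 each give only a limit: the limit of < 100000 nM in this assay, at which 3 of the 4 values shown sit.

The compounds shown leave open how far compound 3 and compound 4 lie from compound 1 in this assay, and whether these exchanges on the shared core change the read-out at all.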